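The source may hold more compounds than are shown below. What is called first, only, known or untested is meant among the compounds shown, and "the series" means these compounds.

Working notes on a small series built on one shared core. Compound 1 `Cc1cccc(Sc2ccnc(-c3ccccn3)n2)c1` gives 2300 nM in a functional assay for inhibition of metabotropic glutamate receptor 5 (Homo sapiens), read by FLIPR and calcium flux; on this read-out higher numbers stand for weaker inhibition and lower numbers for stronger inhibition. Compound 2 `Cc1cccc(-c2nccc(Sc3ccc(Cl)c(Cl)c3)n2)n1` gives 390 nM in this assay, so of the two numbers shown compound 1 stands at the higher one, and the gap down to compound 2, the nearest neighbour, lies beyond the usual scatter. Compound 3 `Clc1ccc(Nc2ccnc(-c3ccccn3)n2)cc1` in this assay sits at the limit of > 10000 nM in this assay, at which 1 of the 3 values shown sits, which is a limit of the assay and not a number. Compound 3 is recorded as > 10000 nM in this assay.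

Compound 4 `FC(F)(F)c1cccc(Sc2ccnc(-c3ccccn3)n2)c1` differs from compound 1 in one place: trifluoromethyl in place of methyl on an aromatic carbon. Among the measured compounds shown here, no pair of measured compounds shows this change, so nothing within the set fixes its size or direction. The expected step is a 1.5-fold lower number from compound 1 to compound 4 (0.19 log units; within the scatter), small and not clearly beyond the scatter in either direction. Compound 4 is therefore estimated at 1500 nM in this assay, with a range from 500 nM to 5000 nM.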

Compound 4, half-maximal inhibitory concentration: 550 nM
The estimate for compound 4 lay 2.7-fold (0.44 log units) above the measured number; the range from low to high includes it.
By their numbers in this assay, from the lowest: compounds 2 and 4 (each within the scatter of the next); then compound 1. At a limit, above all of these: compound 3.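

Trifluoromethyl in place of methyl on an aromatic carbon, meta to a large group, gives a 4.2-fold lower number from compound 1 to compound 4 (0.62 log units; beyond the scatter) in this assay, the first step in the series that can be read at a single place. Among the compounds shown here, this position therefore takes the larger group with stronger inhibition, and the change moves the number beyond the scatter, which no earlier compound could show. Nothing measured in the series accounts for this step.

Going by these compounds, whether the gain belongs to trifluoromethyl alone remains open, as one step at one position says nothing about a methoxy group or an amine on the same carbon. Steps involving compound 2 or compound 3 cannot be read: each differs from the other compounds in more than one place.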